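Replacing the hydroxyphenyl of compound 3 with a piperidinyl

A few compounds are considered here, and "the series" means these few. Any claim that something is new, unique, unknown or untested is made for them only; others in the source may bear on it.

The series shares one core, carried by compound 1 `Cn1cc(-c2cnc3[nH]cc(-c4ccc(Cl)cc4)c3c2)cn1`, compound 2 `Cn1cc(-c2cnc3[nH]cc(-c4cccc(N)c4)c3c2)cn1` and compound 3 `Cn1cc(-c2cnc3[nH]cc(-c4ccc(O)cc4)c3c2)cn1`, and the three differ only in the group attached to the five-membered ring. In a physicochemical assay for solubility, read by LC-MS, in phosphate buffer, measured as thermodynamic solubility, with a stated time of 24 h, at pH 7.4 (on this read-out higher numbers stand for higher solubility and lower numbers for lower solubility), compound 1 gives 800 nM, while compound 2 gives 300000 nM. For compound 3 this assay records only a limit, < 3000 nM, so its position among the three is known just as a ceiling (the limit of < 3000 nM in this assay, at which 1 of the 3 values shown sits). The measured steps around it are a 380-fold higher number from compound 1 to compound 2 (2.57 log units; beyond the scatter), a step that the limit leaves unreadable from compound 1 to compound 3 and an at least 100-fold lower number from compound 2 to compound 3 (2.00 log units; beyond the scatter).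

Compound 4 `Cn1cc(-c2cnc3[nH]cc(C4CCNCC4)c3c2)cn1` is the next, not yet measured, member. Its change from compound 3 is piperidin-4-yl in place of 4-hydroxyphenyl on an aromatic carbon. Going by the values given here, of the measured steps, the one from compound 2 to compound 3 bears most directly on it, since compound 2, which carries an aminophenyl, stands far above the limit seen for compound 3, and compound 1 sits low as well. On that basis a large rise in this assay is expected, and the step is estimated as an at least 33-fold higher number from compound 3 to compound 4 (1.52 log units; beyond the scatter). Compound 4 is therefore expected to reach about 100000 nM, within a range from 15000 nM to 500000 nM.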

Compound 4, solubility: 770000 nM
Beside the measured number, compound 4's estimate is 7.7-fold (0.89 log units) below it; the measured number lies above the stated range.
By their numbers in this assay, from the lowest: compound 1; then compound 2; then compound 4.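

Compared with the aminophenyl of compound 2, which held the highest reading so far at this aromatic carbon of the five-membered aromatic ring, the non-aromatic piperidin-4-yl goes further in this assay, with a 2.6-fold higher number from compound 2 to compound 4 (0.41 log units; beyond the scatter), and against the 4-chlorophenyl the same group gives a 960-fold higher number from compound 1 to compound 4 (2.98 log units; beyond the scatter). An aromatic ring at this place is therefore not needed for a high number, and the change from 4-hydroxyphenyl to piperidin-4-yl, although the two groups are counted with the same hydrogen-bond donors and acceptors, gives an at least 250-fold higher number from compound 3 to compound 4 (2.40 log units; beyond the scatter), a size that stands only as a minimum. Compound 3 is recorded only as a limit: the limit of < 3000 nM in this assay, at which 1 of the 4 values shown sits.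

The compounds shown do not separate the nitrogen of the piperidin-4-yl from the loss of the aromatic ring, a question that a cyclohexyl group at the same place would address. From the compounds shown here alone, it also stays open how far the number depends on that free ring nitrogen, which a piperidin-4-yl carrying a methyl group or an acetyl group on its nitrogen would test.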